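The source may report more compounds than this note shows. Statements on the series, on what has been measured and on what is new or still open speak of the compounds shown alone.

Of the compounds shown here, three have been measured in an assay on NIH3T3 cells with Urotensin-2 receptor (Homo sapiens) as the target; on this read-out lower numbers stand for smaller maximal responses and higher numbers for larger maximal responses. Compound 1 `CN(C)CCC(NC(=O)c1ccc(Oc2ccccc2)cc1)c1ccc(Cl)cc1` gives 89%, compound 2 `Cc1ccccc1NC(=O)OC(CCN(C)C)c1ccc(Cl)cc1` gives 176%, and compound 3 `CN(C)CCC(NC(=O)Nc1ccc(C(F)(F)F)cc1)c1ccc(Cl)cc1` gives 105%. Among these three numbers compound 3 stands second highest. Its nearest neighbour is compound 1, whose number lies lower, beyond the scatter; the furthest is compound 2, whose number lies higher, again beyond the scatter. For the measured compounds named here, compound 2 differs from the other two in several places at once, so no single step between measured compounds is available.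

The step now followed leads from compound 3 to compound 4 `CN(C)CCC(NC(=O)Nc1ccc(Oc2ccccc2)cc1)c1ccc(Cl)cc1`. The change is phenoxy in place of trifluoromethyl on an aromatic carbon. The closest guide is compound 1, which also carries phenoxy on the same position of its aryl ring but is linked through an amide rather than a urea. Since compound 1 gives 89% and compound 3 gives 105%, the two phenoxy-bearing or urea-bearing neighbours bracket a modest region. For compound 4 a small downward shift, or none beyond the scatter, is expected in this assay. This estimate means that the step of a number 7 percentage points lower from compound 3 to compound 4 (within the scatter) is expected to stay within the usual scatter. Compound 4 is therefore estimated at 98%, with a range from 72% to 128%.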

Compound 4, largest response reached (reported as efficacy), in percent of the reference or control that the assay uses: 108%
Beside the measured number, compound 4's estimate is 10 percentage points below it; low and high end bracket the measured number.
By their numbers in this assay, from the lowest: compound 1; then compounds 3 and 4 (each within the scatter of the next); then compound 2.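

In this assay, for the compounds shown here, the exchange of trifluoromethyl for phenoxy on an aromatic carbon, para to a large group, gives a number 3 percentage points higher from compound 3 to compound 4 (within the scatter) and is the first step in this set that changes one place only. On the urea-linked compounds, then, this position carries either a group of 4 heavy atoms with no ring or one of 7 heavy atoms with a six-membered aromatic ring and 1 hydrogen-bond acceptor, and the two numbers stay within the scatter of each other. Nothing measured here speaks to why the two groups read out alike.

The compounds shown leave open how other groups on this carbon, such as methoxy, an amine or a carboxylic acid, would read out, as only trifluoromethyl and phenoxy appear there on the urea-linked compounds. Also open, going by these compounds, is what the link itself contributes: with phenoxy on the ring, compound 1, an amide, gives 89% and compound 4, a urea, gives 108% in this assay, and this single pair cannot say whether the same holds with other groups on that ring.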